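The source may report more compounds than this note shows. Statements on the series, on what has been measured and on what is new or still open speak of the compounds shown alone.

Compound 1, `CCC(C)(CC)/N=C(\NC#N)Nc1cccnc1`, was examined in a functional assay on the whole organism (blood, strain Wistar-Okamoto) with Rattus norvegicus as the target, with a stated time of 5 days (a higher number here means that more compound is needed for the effect, a lower number that less compound is needed), and in that test compound 1 gives 0.5 mg/kg. Compound 3, `CCC(C)(CC)/N=C(\NC#N)Nc1ccncc1`, shares the same atoms joined differently: the difference between the two cores is pyridin-4-yl in place of pyridin-3-yl on an amine nitrogen. In this assay compound 3 gives 0.5 mg/kg, so that no change at the digits printed from compound 1 to compound 3 (within the scatter). Compound 2, `N#CN/C(=N\c1ccccc1)Nc1cccnc1`, carries a different group on the double-bonded nitrogen, namely (phenyl in place of 1-ethyl-1-methylpropyl on a double-bonded nitrogen). In this assay compound 2 gives 5 mg/kg, which means that a 10-fold higher number from compound 1 to compound 2 (1.00 log units; beyond the scatter).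

Compound 4, `N#CN/C(=N\c1ccccc1)Nc1ccncc1`, has not yet been measured in this assay. It stands to compound 3 as compound 2 stands to compound 1: the change is phenyl in place of 1-ethyl-1-methylpropyl on a double-bonded nitrogen, and since the surroundings of the place of change are the same in both pairs, it is the same change, made here on the core of compound 3 rather than on the core of compound 1. For the measured compounds named here, the one measured instance of this change is a 10-fold higher number from compound 1 to compound 2 (1.00 log units; beyond the scatter), and the two cores behave alike in the measured pair, because no change at the digits printed from compound 1 to compound 3 (within the scatter). On that basis the step from compound 3 to compound 4 is expected to be a 10-fold higher number from compound 3 to compound 4 (1.00 log units; beyond the scatter). Compound 4 is therefore estimated to give 5 mg/kg in this assay, with the likely range estimated to run from 2 mg/kg to 12 mg/kg.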

Compound 4, minimum effective dose: 50 mg/kg
Estimate against measurement, compound 4: 10-fold (1.00 log units) below, and the stated range ends below it.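

In this assay, phenyl in place of 1-ethyl-1-methylpropyl on a double-bonded nitrogen gives a 100-fold higher number from compound 3 to compound 4 (2.00 log units; beyond the scatter), so the size of this step does not carry over from one core to the other: the same change on two cores in this assay, a 10-fold higher number (1.00 log units; beyond the scatter) from compound 1 to compound 2 and a 100-fold higher number (2.00 log units; beyond the scatter) from compound 3 to compound 4, 10-fold (1.00 log units) apart, beyond the scatter of two such steps. Seen from the other side, pyridin-4-yl in place of pyridin-3-yl on an amine nitrogen gives a 10-fold higher number from compound 2 to compound 4 (1.00 log units; beyond the scatter), although the same change left the numbers level when the double-bonded nitrogen carried 1-ethyl-1-methylpropyl: the same change on two cores in this assay, no change at the digits printed (within the scatter) from compound 1 to compound 3 and a 10-fold higher number (1.00 log units; beyond the scatter) from compound 2 to compound 4, 10-fold (1.00 log units) apart, beyond the scatter of two such steps. These two comparisons are one gap seen from two sides of the same four compounds: phenyl raises the number on both cores, so the direction carried over, but the size did not, and a level pair of cores proved no safe guide to a second change, though the data do not show why the steps differ or whether the same holds for other groups.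

The compounds shown leave open whether a cyclohexyl ring or a tert-butyl group on the double-bonded nitrogen would follow 1-ethyl-1-methylpropyl or phenyl in how the two pyridine attachments compare. Also open, on these data alone, is how a plain phenyl on the amine nitrogen would compare with pyridin-3-yl and pyridin-4-yl in each of these settings.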